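This account rests on a few compounds, and the source may have more. Where it says the series, first, only, none or still open, it means among the compounds named here.

Compound 3 `CN(Cc1ccccc1)CC1CCN(CCCc2c[nH]c3ccc(-n4cnnc4)cc23)CC1` gives the lowest number of the three compounds in an assay on CHO cells for displacement of a labelled ligand from 5-hydroxytryptamine receptor 1D (Homo sapiens) (a higher number here means a weaker inhibitor, a lower number a stronger inhibitor), at 0.9 nM. Compound 1 `CC(C)=CCCN(C)C1CCN(CCCc2c[nH]c3ccc(-n4cnnc4)cc23)CC1` gives 2.6 nM in this assay, and compound 2 `O[C@@H]1Cc2ccccc2[C@H]1NC1CCN(CCCc2c[nH]c3ccc(-n4cnnc4)cc23)CC1` gives 6.6 nM. The steps that lead to compound 3 were modest: a 2.9-fold lower number from compound 1 to compound 3 (0.46 log units; beyond the scatter) and a 7.3-fold lower number from compound 2 to compound 3 (0.87 log units; beyond the scatter), both replacing the group on the saturated ring carbon.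

Compound 4 `c1cncc(CNC2CCN(CCCc3c[nH]c4ccc(-n5cnnc5)cc34)CC2)c1` changes that same position once more: ((pyridin-3-yl)methyl)amino in place of (benzyl(methyl)amino)methyl on a saturated ring carbon. Within the data shown here, no measured step copies this change. Among the measured compounds shown here, the nearest precedent is compound 2, whose group on the saturated ring carbon also carries a hydrogen-bond donor at the amino nitrogen and sits directly on the ring; the step of a 7.3-fold lower number from compound 2 to compound 3 (0.87 log units; beyond the scatter) shows how far that kind of group stood behind compound 3. The two steps into compound 3 therefore point the same way, and compound 4 is expected to give a somewhat higher number, with a 3.9-fold higher number from compound 3 to compound 4 (0.59 log units; beyond the scatter) estimated as the step. Compound 4 is estimated at 3.5 nM in this assay, with a range from 1.2 nM to 10 nM.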

Compound 4, half-maximal inhibitory concentration: 35 nM
Compound 4: middle estimate off by 10-fold (1.00 log units), on the low side; measured number outside the range, above it.
By their numbers in this assay, from the lowest: compound 3; then compound 1; then compound 2; then compound 4.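

In this assay, the group on the saturated ring carbon can move the number further than the earlier compounds showed, with a 39-fold higher number from compound 3 to compound 4 (1.59 log units; beyond the scatter), the largest step among the compounds shown. The other two steps run the same way, a 13-fold higher number from compound 1 to compound 4 (1.13 log units; beyond the scatter) and a 5.3-fold higher number from compound 2 to compound 4 (0.72 log units; beyond the scatter), the latter exchanging 2-hydroxy-2,3-dihydro-1H-inden-1-yl for (pyridin-3-yl)methyl on an amine nitrogen, so the hydrogen on that nitrogen, present in both compound 2 and compound 4, does not by itself set the number. No measurement at hand accounts for any of these steps.

The compounds shown leave open which part of the change carries the large step from compound 3. A benzylamino group on the same ring carbon, or a methyl on the amine nitrogen of the ((pyridin-3-yl)methyl)amino group, would help to separate the ring from the amine.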